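From bromo to nitro on the shared core

This account rests on a few compounds, and the source may have more. Where it says the series, first, only, none or still open, it means among the compounds named here.

compound 1 `O=C(Cc1ccc(Cl)cc1)NS(=O)(=O)C(F)(F)F` gives 49 mg/kg
compound 2 `O=C(Cc1ccc(Br)cc1)NS(=O)(=O)C(F)(F)F` gives 55 mg/kg

Among the measured compounds shown here, in a functional assay on the whole organism with Mus musculus as the target (on this read-out higher numbers stand for an effect only at larger amounts of compound and lower numbers for an effect already at smaller amounts), compound 2 stands level with compound 1, and only one step between measured compounds is available: a 1.1-fold higher number from compound 1 to compound 2 (0.05 log units; within the scatter), with bromo in place of chloro on an aromatic carbon. Compound 3 `O=C(Cc1ccc([N+](=O)[O-])cc1)NS(=O)(=O)C(F)(F)F` has not yet been measured. It carries nitro in place of bromo on an aromatic carbon, para to a large group (nitro in place of bromo on an aromatic carbon). For the measured compounds named here, the measured step bears on this change only loosely, since it exchanges chloro for bromo and no measured compound carries nitro. From the compounds shown here alone, with so little evidence, no step beyond the scatter is expected in this assay and the direction remains open. The estimated step is a 1.1-fold higher number from compound 2 to compound 3 (0.04 log units; within the scatter) on this evidence. Compound 3 is expected at 60 mg/kg with an estimated range from 25 mg/kg to 140 mg/kg, a wide span for a single small data set.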

Compound 3, dose for half-maximal effect: 20 mg/kg
Compound 3: the middle estimate sits 3.0-fold (0.48 log units) above what was measured; measured number below the stated range.
By their numbers in this assay, from the lowest: compound 3; then compounds 1 and 2 (each within the scatter of the next).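

In this assay the group on this aromatic carbon, para to a large group, proves able to shift the dose: nitro in place of bromo gives (a 2.8-fold lower number from compound 2 to compound 3 (0.44 log units; beyond the scatter)) and nitro in place of chloro gives (a 2.5-fold lower number from compound 1 to compound 3 (0.39 log units; beyond the scatter)). Among the compounds shown here, the earlier pair showed only that one halogen can stand in for the other without a change beyond the scatter, so this is the first sign that the position is not indifferent to what it carries. Nothing measured here says why nitro stands apart from the two halogens.

From the compounds shown here alone, whether a smaller effective dose belongs to nitro alone, or would also come with a nitrile, an amine or a carboxylic acid on the same carbon, stays open. So does whether nitro would give a step of similar size with another group in place of the trifluoromethyl.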